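Carboxyphenoxy variation on the shared core

The compounds below may be only part of what the source reports. "The series", "measured", "known", "first", "only" and "open" are said of these compounds alone.

Among the measured compounds shown here, only two compounds carry numbers so far. In a functional assay on HEK293 cells for agonist activity at Bile acid receptor (Homo sapiens) (on this read-out higher numbers stand for larger maximal responses and lower numbers for smaller maximal responses), compound 2 `O=C(O)c1ccccc1OCc1ccc(OCc2c(-c3c(Cl)cccc3Cl)noc2C2CC2)nc1C(F)(F)F` gives 63%; compound 1 `CCN(Cc1ccc(C(=O)O)cc1)c1ccc(OCc2c(-c3c(Cl)cccc3Cl)noc2C2CC2)nc1C(F)(F)F` gives 54%, a gap that lies within the scatter, so neither compound stands apart from the other. Compound 3 `CC(Oc1ccc(C(=O)O)cc1)c1ccc(OCc2c(-c3c(Cl)cccc3Cl)noc2C2CC2)nc1C(F)(F)F` is not yet measured and differs from compound 2 by 1-(4-carboxyphenoxy)ethyl in place of (2-carboxyphenoxy)methyl on an aromatic carbon. For the measured compounds named here, no step between measured compounds covers this change. Because compound 1 at 54% and compound 2 at 63% sit within the scatter of each other, a step of a number 5 percentage points lower from compound 2 to compound 3 (within the scatter) is expected, none beyond the scatter. Compound 3 is estimated at 58% in this assay, in the range 38% to 78%.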

Compound 3, largest response reached (reported as efficacy), in percent of the reference or control that the assay uses: 70%
The estimate for compound 3 lay 12 percentage points below the measured number; the range from low to high includes it.
By their numbers in this assay, from the lowest: compounds 1, 2 and 3 (each within the scatter of the next, the first and the last beyond it).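

In this assay the change to 1-(4-carboxyphenoxy)ethyl on this aromatic carbon, ortho to a trifluoromethyl group, gives a number 7 percentage points higher from compound 2 to compound 3 (within the scatter) and shows that this position accepts both carboxyphenoxy groups with no step beyond the scatter. Among the compounds shown here, the change alters both the chain and the place of the carboxylic acid on the phenyl ring, and the single step does not separate the two. Nothing measured here bears on the origin of this step.

Open, from the compounds shown here alone, is how 1-(2-carboxyphenoxy)ethyl or (4-carboxyphenoxy)methyl would read in this assay to separate those two alterations. Also open, going by these compounds, is whether a tetrazole could stand in for the carboxylic acid at this position.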